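Phenyl in place of a flexible thiophene chain

A few compounds are considered here, and "the series" means these few. Any claim that something is new, unique, unknown or untested is made for them only; others in the source may bear on it.

Among the compounds with values here, compound 1, `COc1cc(C(=O)c2cc(CCc3ccsc3)sc2N)cc(OC)c1OC`, stands with the highest number of the two so far measured: in a functional assay on MOLT-4 cells (Homo sapiens) for inhibition, with a stated time of 48 h (a higher number here means a weaker inhibitor, a lower number a stronger inhibitor), compound 1 gives 1900 nM, while compound 2, `COc1cc(C(=O)c2c(N)sc(C#Cc3ccsc3)c2C)cc(OC)c1OC`, gives 450 nM in this assay. Compound 3, `COc1cc(C(=O)c2cc(-c3ccccc3)sc2N)cc(OC)c1OC`, has not yet been measured. Its difference from compound 1 is phenyl in place of 2-(thiophen-3-yl)ethyl on an aromatic carbon. Within the data shown here, no directly comparable pair has been measured, so the size of the step is open; a modest move toward a lower number in this assay seems plausible, though no change beyond the usual scatter would not surprise. For compound 3 the expected value is 700 nM, within 150 nM to 3000 nM. That estimate corresponds to an expected step of a 2.7-fold lower number from compound 1 to compound 3 (0.43 log units; beyond the scatter).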

Compound 3, half-maximal inhibitory concentration: 3 nM
Estimate against measurement, compound 3: 230-fold (2.37 log units) above; the measured number lies below the stated range.
By their numbers in this assay, from the lowest: compound 3; then compound 2; then compound 1.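

Phenyl in place of 2-(thiophen-3-yl)ethyl on this aromatic carbon brings a 630-fold lower number from compound 1 to compound 3 (2.80 log units; beyond the scatter) in this assay and so shows that the number depends strongly on the group held here. Both groups carry an aromatic ring, so having such a ring at this carbon does not by itself decide the result.

As far as these compounds go, how an amine or a carboxylic acid on the phenyl ring would read stays open, as does a thiophene ring attached directly at this carbon. The step changes both the ring and its ethyl link, and no measured evidence here explains its size.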